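This account rests on a few compounds, and the source may have more. Where it says the series, first, only, none or still open, it means among the compounds named here.

Three compounds have been measured in a toxicity assay on HepG2 cells (Homo sapiens) for inhibition, read by CellTiter-Glo, with a stated time of 48 h; a lower number here means a stronger inhibitor, a higher number a weaker inhibitor:

Compound 1, `CSc1ccc2nc(C)cc(OCC(=O)Nc3cc(C)cc(C)c3)c2c1`, gives a value that is a limit of the assay, > 100000 nM.
Compound 2, `Cc1cc(C)cc(NC(=O)COc2cc(C)nc3ccc(OC(F)(F)F)cc23)c1`, gives a value that is likewise a limit, > 100000 nM.
Compound 3, `COc1ccc2nc(C)cc(OCC(=O)NCc3cc(C)cc(C)c3)c2c1`, gives a value that is also a limit, > 100000 nM.

Compound 3 therefore stands at the limit of > 100000 nM in this assay, at which 3 of the 3 values shown sit, and no number is known for it. Compound 4, `COc1ccc2nc(C)cc(OCC(=O)Nc3cc(C)ccc3C)c2c1`, differs from it by 2,5-dimethylphenyl in place of 3,5-dimethylbenzyl on an amide-type nitrogen. No measured step shares this change; the only step shown, a step that the two limits leave unreadable from compound 1 to compound 2, concerns another part of the core and is unreadable. Since every measured compound sits at the limit, the author expects no readable step that the limit leaves unreadable from compound 3 to compound 4 in this assay. He estimates compound 4 at 150000 nM, with a range from 50000 nM to 400000 nM, most likely reported again as a limit.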

Compound 4, half-maximal inhibitory concentration: > 100000 nM
Compound 4: a limit, no number; the forecaster's own chance of this, stated with the estimate: 85%; the middle value does not contradict the limit.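

The step between compound 3 and compound 4 cannot be read, since both values are limits of this assay, not numbers: the limit of > 100000 nM in this assay, at which 4 of the 4 values shown sit.

The compounds shown leave open whether any change to the shared core or its amide side would give a readable value in this assay.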